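The compounds below may be only part of what the source reports. "The series", "measured", "known", "first", "only" and "open" are said of these compounds alone.

Compounds measured so far:
Compound 1, `COc1ccc(C#Cc2ccc(C(=O)N3CCC[C@@H](CO)C3)cc2)c(F)c1F`. In a functional assay on TREX cells for negative allosteric modulation of metabotropic glutamate receptor 3 (Rattus norvegicus), read by calcium flux, with a stated time of 2.5 min (a lower number here means a stronger inhibitor, a higher number a weaker inhibitor), compound 1 gives > 10000 nM, which is a limit of the assay rather than a number.
Compound 2, `COc1ccc(C#Cc2ccc(C(=O)N3CCC[C@@H](CO)C3)cc2)cc1F`. In this assay compound 2 gives > 10000 nM, again a limit and not a number.

Compound 2 thus stands at the limit of > 10000 nM in this assay, at which 2 of the 2 values shown sit, and no actual number is known for it. Among the compounds with values here, the single measured step, a step that the two limits leave unreadable from compound 1 to compound 2, is unreadable for the same reason: it records hydrogen in place of fluoro on an aromatic carbon, but its size cannot be told. Compound 3, `CSc1ccc(C#Cc2ccc(C(=O)N3CCC[C@@H](CO)C3)cc2)cc1`, has not yet been measured in this assay. It differs from compound 2 by 4-(methylsulfanyl)phenyl in place of 3-fluoro-4-methoxyphenyl on a triple-bonded carbon. Within the data shown here, no measured step bears on this change, and the one recorded step has no readable size, so there is no basis for expecting a move beyond the scatter in either direction. The estimate for compound 3 is 15000 nM, within a range from 3000 nM to 60000 nM, most likely again reported only as a limit. The step this estimate means, a step that the limit leaves unreadable from compound 2 to compound 3, is expected to be negligible.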

Compound 3, half-maximal inhibitory concentration: > 10000 nM
Compound 3: no number, only a limit; the forecaster's own chance of this, stated with the estimate: 75%; the middle value lies beyond the limit too.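

In this assay compound 3 gives > 10000 nM, a limit and not a number, so no step can be read between compound 2 and compound 3. The compounds shown leave open how strongly any of them inhibits, since none has a measured number: the limit of > 10000 nM in this assay, at which 3 of the 3 values shown sit.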